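The source may hold more compounds than are shown below. What is called first, only, known or untested is meant among the compounds shown, and "the series" means these compounds.

Measured so far in an in vitro ADME assay on microsomes from liver (Homo sapiens) for metabolic stability, using NADPH; on this read-out higher numbers stand for fast clearance and lower numbers for slow clearance:
compound 1 `CC(C)(CO)CNC(=O)c1cc2cc(C#N)ccc2n1Cc1cccc(OC(F)(F)F)c1` — 62 mL.min-1.g-1
compound 2 `CCOc1ccc(OC(F)(F)F)cc1Cn1c(C(=O)NCC(C)(C)CO)cc2cc(C#N)ccc21` — 103 mL.min-1.g-1

Within the data shown here, compound 1 gives the lowest of the two numbers, and its only neighbour is compound 2, which differs from it by ethoxy in place of hydrogen on an aromatic carbon and lies a 1.7-fold higher number from compound 1 to compound 2 (0.22 log units; within the scatter). On the read-out of this assay the two compounds are therefore indistinguishable.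

The step now followed leads from compound 1 to compound 3 `CC(O)C1(CNC(=O)c2cc3cc(C#N)ccc3n2Cc2cccc(OC(F)(F)F)c2)CCCC1`. The change is a group of 8 heavy atoms (7 carbon, 1 oxygen; one five-membered non-aromatic ring of carbon only) in place of a group of 5 heavy atoms (4 carbon, 1 oxygen; no ring), on a saturated chain carbon bound to an amide-type nitrogen. Among the measured compounds shown here, no measured step touches this part of the molecule: the one step available, from compound 1 to compound 2, concerns an aromatic carbon and stays within the scatter, so it offers no guidance on what the new group on the chain carbon bound to the amide-type nitrogen will do. The expectation for compound 3 therefore rests on the value of compound 1 alone, 62 mL.min-1.g-1, with a wide range around it and without a direction that the data would support. Compound 3 is accordingly expected at 80 mL.min-1.g-1, between 35 mL.min-1.g-1 and 180 mL.min-1.g-1. This estimate corresponds to a step of a 1.3-fold higher number from compound 1 to compound 3 (0.11 log units; within the scatter), which is not expected to exceed the scatter.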

Compound 3, intrinsic clearance in microsomes: 505 mL.min-1.g-1
Compound 3: the middle estimate sits 6.3-fold (0.80 log units) below what was measured, and the stated range ends below it.
By their numbers in this assay, from the lowest: compounds 1 and 2 (each within the scatter of the next); then compound 3.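

Among these compounds, the chain carbon bound to an amide-type nitrogen proves to be a place where the read-out of this assay responds strongly: the group of 8 heavy atoms with its five-membered non-aromatic ring, in place of 1-(hydroxymethyl)-1-methylethyl, gives an 8.1-fold higher number from compound 1 to compound 3 (0.91 log units; beyond the scatter) and so moves beyond the scatter, whereas the only earlier step, on an aromatic carbon, gave a 1.7-fold higher number from compound 1 to compound 2 (0.22 log units; within the scatter) and did not. The leaving and entering groups have the same counts of hydrogen-bond donors and acceptors and the same lack of net charge, so the step goes with a difference in heavy atoms and ring while those counts stay the same. Nothing among the data shown accounts for the rise in clearance.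

Since the ring and the larger heavy-atom count arrive together in this one step, the compounds shown do not separate what each contributes, nor do they show whether a smaller carbon ring such as cyclopropyl on this chain carbon would give a step of similar size. They also leave open how an amine or a carboxylic acid in place of the hydroxyl would read in this assay and whether the ethoxy group on the aromatic carbon would behave the same alongside the new group.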